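Amide chain length on the diaryl ether series

The compounds below may be only part of what the source reports. "The series", "measured", "known", "first", "only" and "open" are said of these compounds alone.

In an assay on isolated protein for binding affinity to melatonin receptor type 1B (Homo sapiens) (a higher number here means a weaker inhibitor, a lower number a stronger inhibitor), compound 1 `CCCC(=O)Nc1ccc(Oc2cccc(OC)c2)cc1` gives 0.75 nM. Compound 3 `COc1cccc(Oc2ccc(NC(C)=O)cc2)c1` gives 4.1 nM in this assay and stands highest of the two numbers shown, with compound 1 nearest at a 5.5-fold higher number from compound 1 to compound 3 (0.74 log units; beyond the scatter). Compound 2 `CCCC(=O)Nc1ccc(Oc2ccc(OC)cc2)cc1` returns only a limit, > 400 nM, which is the limit of > 400 nM in this assay, at which 1 of the 3 values shown sits. Compound 4 `CCC(=O)Nc1ccc(Oc2cccc(OC)c2)cc1` is not yet measured; it differs from compound 3 by methyl in place of hydrogen on a saturated chain carbon bound to a carbonyl carbon. Among the measured compounds shown here, the one measured step that bears on this change is a 5.5-fold higher number from compound 1 to compound 3 (0.74 log units; beyond the scatter), which removes a longer chain at the same place and runs in the opposite direction. A step of a 2.7-fold lower number from compound 3 to compound 4 (0.44 log units; beyond the scatter) is therefore expected, smaller than that measured step and downward. Compound 4 is estimated at 1.5 nM in this assay, between 0.7 nM and 3.5 nM.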

Compound 4, inhibition constant: 6.8 nM
The estimate for compound 4 lay 4.5-fold (0.66 log units) below the measured number; measured number outside the range, above it.
By their numbers in this assay, from the lowest: compound 1; then compounds 3 and 4 (each within the scatter of the next). At a limit, above all of these: compound 2.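

Adding methyl to the acetamido chain gives no readable change (in a 1.7-fold higher number from compound 3 to compound 4 (0.22 log units; within the scatter)), so the propanoylamino chain of compound 4 does not separate from the acetamido chain of compound 3. The effect of chain length appears only with the further carbon of compound 1 (see a 9.1-fold higher number from compound 1 to compound 4 (0.96 log units; beyond the scatter)), so the response is uneven along the chain rather than graded with each added carbon. Nothing in hand accounts for this unevenness.

From the compounds shown here alone, whether a longer chain such as pentanoyl holds, extends or reverses the effect stays open. So does whether a branched chain or a cyclopropyl group matches the straight chain of compound 1.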